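Trifluoromethyl to fluoro on the aryl ring of compound 3

This account rests on a few compounds, and the source may have more. Where it says the series, first, only, none or still open, it means among the compounds named here.

Compound 1 `COc1ccc(N/C=C\C(=O)c2nc(-c3ccc(F)cc3)n3ccccc23)cc1`: in a functional assay on HCT-116 cells (Homo sapiens) for cytotoxicity, read by MTT assay, with a stated time of 48 h (on this read-out lower numbers stand for stronger inhibition and higher numbers for weaker inhibition), compound 1 gives > 30000 nM, a limit of the assay.
Compound 2 `COc1ccc(-c2nc(C(=O)/C=C\Nc3ccc(Cl)cc3)c3ccccn23)cc1`: in this assay compound 2 gives > 30000 nM, again a limit.
Compound 3 `O=C(/C=C\Nc1ccc(Cl)cc1)c1nc(-c2ccc(C(F)(F)F)cc2)n2ccccc12`: in this assay compound 3 gives 11500 nM.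

Among the measured compounds shown here, compound 3 holds the only numerical value; the other two readings sit at a limit (the limit of > 30000 nM in this assay, at which 2 of the 3 values shown sit). For the measured compounds named here, the one measured step, an at least 2.6-fold lower number from compound 2 to compound 3 (0.41 log units; beyond the scatter), shows that the group on this aromatic carbon changes the read-out beyond the scatter. Compound 4 `O=C(/C=C\Nc1ccc(Cl)cc1)c1nc(-c2ccc(F)cc2)n2ccccc12` carries fluoro in place of trifluoromethyl on an aromatic carbon. Going by the values given here, no measured step covers this exact exchange; compound 1, which also bears fluoro here but differs elsewhere too, shows only a limit. A modest move toward a higher number is therefore expected, a 2.2-fold higher number from compound 3 to compound 4 (0.34 log units; beyond the scatter), and compound 4 is estimated at 25000 nM, between 9000 nM and 60000 nM.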

Compound 4, half-maximal inhibitory concentration: 1210 nM
Compound 4: middle estimate off by 21-fold (1.32 log units), on the high side; measured number below the stated range.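

In this assay, fluoro in place of trifluoromethyl gives a 9.5-fold lower number from compound 3 to compound 4 (0.98 log units; beyond the scatter), so the group on this aromatic carbon moves the read-out further than the earlier step showed, and compound 4 has the lowest number of the four. Fluoro in place of methoxy on this carbon gives an at least 24-fold lower number from compound 2 to compound 4 (1.39 log units; beyond the scatter), and chloro in place of methoxy at a second place gives an at least 24-fold lower number from compound 1 to compound 4 (1.39 log units; beyond the scatter). Both steps start from a limit and are bounds only: the limit of > 30000 nM in this assay, at which 2 of the 4 values shown sit.

The compounds shown leave open how an unsubstituted phenyl or an amine on this carbon would read. They also leave open whether fluoro keeps its advantage when the chloro is replaced by a bromo.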